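Two Diacetyl Thioesters Measured, a Chloroanilide Awaiting Test

The compounds below may be only part of what the source reports. "The series", "measured", "known", "first", "only" and "open" are said of these compounds alone.

Compound 1, `CC(=O)SCCC(CCCCC(=O)O)SC(C)=O`: 9.96%
Compound 2, `O=C(CCCCC(S)CCS)NO`: 5.7%

In a functional assay on NCI-H460 cells (Homo sapiens) for inhibition, read by MTT assay, with a stated time of 24 h, tested at 0.1 ug/mL (on this read-out higher numbers stand for more inhibition of growth at the one concentration tested and lower numbers for less inhibition of growth), compound 1 gives 9.96%. In the same read-out compound 2 gives 5.7%, and the gap between the two numbers lies within the usual scatter, so neither compound can be set apart from the other. Within the data shown here, no pair of measured compounds differs in a single place, so no measured step is available to guide the next change.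

Compound 3, `CC(=O)SCCC(CCCCC(=O)Nc1cccc(Cl)c1)SC(C)=O`, differs from compound 1 in one place: (3-chlorophenyl)amino in place of hydroxy on a carbonyl carbon. With both measured numbers low and indistinguishable, the data give no ground for a large move in either direction. The step from compound 1 to compound 3 is expected to be small, a number 2 percentage points higher from compound 1 to compound 3 (within the scatter), within the scatter. Compound 3 is therefore estimated at 12%, with a range from 0% to 30%.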

Compound 3, percent growth inhibition at one concentration: "not active" (no number reported)
For compound 3 the study gives words and no number; no gap can be computed for the estimate.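

In this assay, among these compounds, compound 3 gives "not active" (no number reported) and so no step from compound 1 to compound 3 can be read. The compounds shown leave open whether (3-chlorophenyl)amino in place of hydroxy changes growth inhibition at all. Nothing shown bears on a cause for this result.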